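The compounds below may be only part of what the source reports. "The series", "measured", "known", "first", "only" and "open" are said of these compounds alone.

Three measured compounds share one core, seen in compound 1 `C/C(=C\c1cc(-c2ccc(C)cc2)cs1)C(N)=O`, compound 2 `C/C(=C\c1cc(-c2ccc(S(C)(=O)=O)cc2)cs1)C(N)=O` and compound 3 `C/C(=C\c1cc(-c2ccc(C(F)(F)F)cc2)cs1)C(N)=O`. Among the measured compounds shown here, in a functional assay on MCF7 cells (Homo sapiens) for cytotoxicity, read by CCK-8 assay, with a stated time of 24 h (on this read-out higher numbers stand for weaker inhibition and lower numbers for stronger inhibition), compound 3 gives 50000 nM, the only plain number among the three results. For compound 1 the result in this assay is a limit of the assay, > 50000 nM. For compound 2 the result in this assay is likewise a limit of the assay, > 50000 nM. The step of a number no higher from compound 1 to compound 3 (the limit leaves the size open) and the step of a number no higher from compound 2 to compound 3 (the limit leaves the size open) thus leave their size open, as does a step that the two limits leave unreadable from compound 1 to compound 2; all three rest on (the limit of > 50000 nM in this assay, at which 2 of the 3 values shown sit). Compound 4 `C/C(=C\c1cc(-c2ccc(Cl)cc2)cs1)C(N)=O` differs from compound 3 in one place: chloro in place of trifluoromethyl on an aromatic carbon. For the measured compounds named here, no measured step shows this change, and the two steps that reach compound 3 are unreadable, so no size or direction beyond the scatter can be drawn from them. Compound 4 is therefore expected to remain near the limit, with an expected step of no change at the digits printed from compound 3 to compound 4 (within the scatter). The estimate for compound 4 in this assay is 50000 nM, with a range from 20000 nM to 120000 nM.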

Compound 4, half-maximal inhibitory concentration: 17100 nM
Estimate against measurement, compound 4: 2.9-fold (0.47 log units) above; measured number outside the range, below it.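

At the aromatic carbon para to a large group, the series now has a step of readable size: in this assay, chloro in place of trifluoromethyl gives a 2.9-fold lower number from compound 3 to compound 4 (0.47 log units; beyond the scatter), so the group at this place can move the number beyond the scatter. Chloro also separates from the other two groups, with an at least 2.9-fold lower number from compound 2 to compound 4 (0.46 log units; beyond the scatter) and an at least 2.9-fold lower number from compound 1 to compound 4 (0.46 log units; beyond the scatter), which makes compound 4 the most potent of the four in this assay. Those two steps fix only a smallest size, and the steps among compound 1, compound 2 and compound 3 cannot be read: the limit of > 50000 nM in this assay, at which 2 of the 4 values shown sit.

The compounds shown leave open how a bromo, a methoxy or an amine at this carbon would compare with chloro. They also leave open whether the chloro step would hold if the amide of the shared core were replaced by a carboxylic acid.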